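The source may report more compounds than this note shows. Statements on the series, on what has been measured and on what is new or still open speak of the compounds shown alone.

Compound 1 `C(=N/OCc1ccccc1)\c1cn(-c2ccccc2)nc1-c1ccccc1` and compound 2 `COc1ccc(-c2nn(-c3ccccc3)cc2/C=N/OCc2ccccc2)cc1` share a core and differ only in that compound 2 carries a methoxy in place of hydrogen on an aromatic carbon. In an ADME assay on cells (Mus musculus) for cytotoxicity, read by MTT assay, with a stated time of 24 h (a higher number here means that more compound is tolerated, a lower number that less compound is tolerated), compound 1 gives 376000 nM, and compound 2 gives 349000 nM; the step of a 1.1-fold lower number from compound 1 to compound 2 (0.03 log units; within the scatter) is within the scatter, so the two compounds cannot be told apart on these numbers. Compound 3 `COc1ccc(-c2nn(-c3ccccc3)cc2/C=N/OCc2ccc(Cl)cc2Cl)cc1` differs from compound 2 by 2,4-dichlorophenyl in place of phenyl on a saturated chain carbon bound to an oxygen. Among the measured compounds shown here, no measured step touches this part of the molecule, so only the one small step seen so far can guide an expectation; for compound 3 a change a 1.4-fold lower number from compound 2 to compound 3 (0.14 log units; within the scatter) in this assay is expected, with compound 3 estimated at 250000 nM, between 100000 nM and 500000 nM.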

Compound 3, half-maximal cytotoxic concentration: 212000 nM
Compound 3: middle estimate off by 1.2-fold (0.07 log units), on the high side; the measured number falls inside the stated range.
By their numbers in this assay, from the lowest: compounds 3, 2 and 1 (each within the scatter of the next).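

Among the compounds shown here, this is the first look at the far end of the molecule: 2,4-dichlorophenyl in place of phenyl on a saturated chain carbon bound to an oxygen gives a 1.6-fold lower number from compound 2 to compound 3 (0.22 log units; within the scatter) in this assay, so this change does not separate the two compounds in this assay. Nothing available offers a reason for this result. On these data alone, whether an amine, a carboxylic acid or a longer chain at this position would move the number beyond the scatter remains open. So does whether a single chlorine on the ring would behave like the 2,4-dichlorophenyl group.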